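This account rests on a few compounds, and the source may have more. Where it says the series, first, only, none or still open, it means among the compounds named here.

Measured so far:
compound 1 `CC(C(=O)NCc1ccc(C(C)(C)C)nc1OCc1ccccc1)c1ccc(NS(C)(=O)=O)c(F)c1`: 4.4 nM
compound 2 `CC(C(=O)NCc1ccc(C(C)(C)C)cc1N1CCN(c2ccccc2)CC1)c1ccc(NS(C)(=O)=O)c(F)c1`: 0.8 nM
compound 3 `C[C@@H](C(=O)NCc1ccc(C(C)(C)C)cc1SC1CCCCC1)c1ccc(NS(C)(=O)=O)c(F)c1`: 89.2 nM

In an assay on cells for antagonist activity at transient receptor potential cation channel subfamily V member 1 (Homo sapiens), read by FLIPR and calcium flux, with a stated time of 6 min (on this read-out lower numbers stand for stronger inhibition and higher numbers for weaker inhibition), compound 2 gives the lowest of the three numbers; compound 1 stands beyond the scatter from it, and compound 3 further still, also beyond the scatter. Compound 4 `CC(C(=O)NCc1ccc(C(C)(C)C)cc1C1CCCCC1)c1ccc(NS(C)(=O)=O)c(F)c1` is not yet measured. It differs from compound 2 in one place: cyclohexyl in place of 4-phenylpiperazin-1-yl on an aromatic carbon. Within the data shown here, no pair of measured compounds separated by a single change is available, so the size of the step rests on the spread among compounds 1, 2 and 3 alone. Compound 3, which carries a cyclohexyl on sulfur in the same region, sits at 89.2 nM, far from compound 2. A weakening beyond the scatter is therefore expected, a 31-fold higher number from compound 2 to compound 4 (1.49 log units; beyond the scatter), though smaller than the gap to compound 3. Compound 4 is estimated at 25 nM, within 5 nM to 130 nM.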

Compound 4, inhibition constant: 9.8 nM
Estimate against measurement, compound 4: 2.6-fold (0.41 log units) above, within the range that was stated.
By their numbers in this assay, from the lowest: compound 2; then compound 1; then compound 4; then compound 3.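

In this assay, among these compounds, cyclohexyl in place of 4-phenylpiperazin-1-yl on this aromatic carbon gives a 12-fold higher number from compound 2 to compound 4 (1.09 log units; beyond the scatter) as the first single-change step, so the group at this position clearly affects the read-out. Even so, compound 4 still reads 9.8 nM with neither the piperazine ring nor the phenyl ring present. Nothing available bears on the cause of this step.

It remains open which part of 4-phenylpiperazin-1-yl accounts for the step. An unsubstituted piperazine or a phenyl group on the same carbon would separate the two rings.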